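The source may report more compounds than this note shows. Statements on the series, on what has been measured and on what is new or still open speak of the compounds shown alone.

Compound 1 `COc1ccc([C@@H]2C/C(=N/OCc3cn(-c4ccc(C(=O)c5ccccc5)cc4)nn3)c3cc(CC=C(C)C)c(OC)cc3O2)cc1` gives 52%
Compound 2 `COc1cc2c(cc1CC=C(C)C)C(=O)C[C@@H](c1ccc(Oc3cccc([N+](=O)[O-])c3)cc1)O2` gives 46%
Compound 3 `COc1cc2c(cc1CC=C(C)C)/C(=N/NC(N)=O)C[C@@H](c1ccc(O)cc1)O2` gives 87%

In a functional assay on HCT-116 cells (Homo sapiens) for inhibition, read by sulforhodamine B assay, with a stated time of 48 h, tested at 50 uM (a higher number here means more inhibition of growth at the concentration tested, a lower number less inhibition of growth), compound 1 stands at 52% and within the usual scatter of compound 2 at 46% while compound 3 at 87% lies beyond the scatter above compound 1. The next compound to be tested is compound 4 `COc1ccc([C@@H]2C/C(=N/OCc3cn(-c4ccc(NC(=O)c5ccccc5)cc4)nn3)c3cc(CC=C(C)C)c(OC)cc3O2)cc1` and it departs from compound 1 in a single place. There benzamido in place of benzoyl on an aromatic carbon with benzamido in place of benzoyl on an aromatic carbon, para to a large group. The rest of compound 1 is kept.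

For the measured compounds named here, no two measured compounds differ in only one place, so the data hold no direct measure of this change or of any other. Compound 2 and compound 3 differ from compound 1 in several places and offer little guidance here. The expectation therefore rests on compound 1 at 52% as its starting point. No step beyond the scatter is expected in this assay in either direction. The estimated step of a number 2 percentage points lower from compound 1 to compound 4 (within the scatter) is accordingly small. For compound 4 the expected value is 50% in this reading. The estimated range for compound 4 runs from 33% to 67% at its two ends.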

Compound 4, percent growth inhibition at one concentration: 8%
Beside the measured number, compound 4's estimate is 42 percentage points above it; the measured number lies below the stated range.
By their numbers in this assay, from the lowest: compound 4; then compounds 2 and 1 (each within the scatter of the next); then compound 3.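

In this assay, for the compounds shown here, benzamido in place of benzoyl on an aromatic carbon, para to a large group, comes out as a number 44 percentage points lower from compound 1 to compound 4 (beyond the scatter), and this is the first direct reading of any single change. It shows that this position is not indifferent to what it carries, since the rest of the molecule is kept and the two groups are close in what can be counted: each holds one six-membered aromatic ring of carbon only and one double bond outside aromatic rings, while benzamido adds a nitrogen and a hydrogen-bond donor. No measurement at hand gives a cause for this loss of growth inhibition.

The compounds shown leave open how an amide whose nitrogen carries a methyl group, a sulfonamide or a plain amine on this same aromatic carbon would read in this assay. They also leave open whether the amide nitrogen itself or the larger linkage goes with the drop, and whether a reversed amide would behave like benzamido or like benzoyl.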